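Compound 3 to compound 4: fluoro to methyl

The source may report more compounds than this note shows. Statements on the series, on what has been measured and on what is new or still open speak of the compounds shown alone.

Measured so far in a functional assay on HSC-2 cells (Homo sapiens) for cytotoxicity, with a stated time of 24 h; on this read-out higher numbers stand for lower toxicity in this test and lower numbers for higher toxicity in this test:
- compound 1 `O=C1/C(=C/c2ccccc2)CCC/C1=C\c1ccccc1[N+](=O)[O-]` gives 3800 nM
- compound 2 `Cc1ccc(/C=C2\CCC/C(=C\c3ccccc3[N+](=O)[O-])C2=O)cc1` gives 11000 nM
- compound 3 `O=C1/C(=C/c2ccc(F)cc2)CCC/C1=C\c1ccc([N+](=O)[O-])cc1` gives 19000 nM

Compound 3 lies within the usual scatter of compound 2, and its number is clearly higher than that of compound 1. The next compound, compound 4 `Cc1ccc(/C=C2\CCC/C(=C\c3ccc([N+](=O)[O-])cc3)C2=O)cc1`, differs by methyl in place of fluoro on an aromatic carbon. Going by the values given here, the only measured step bringing in a methyl, a 2.9-fold higher number from compound 1 to compound 2 (0.46 log units; beyond the scatter), was modest, but that methyl replaced hydrogen. Among the compounds with values here, no measured step replaces fluoro, so only a small upward change, possibly none beyond the scatter, is expected in this assay. The expected step is a 1.3-fold higher number from compound 3 to compound 4 (0.10 log units; within the scatter). Compound 4 is estimated at 24000 nM, with an expected range of 10000 nM to 55000 nM.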

Compound 4, half-maximal cytotoxic concentration: 6600 nM
For compound 4 the middle estimate is 3.6-fold (0.56 log units) above the measured one; measured number below the stated range.
By their numbers in this assay, from the lowest: compounds 1, 4, 2 and 3 (each within the scatter of the next, the first and the last beyond it).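

In this assay the change from 4-fluorophenyl to 4-methylphenyl is a 2.9-fold lower number from compound 3 to compound 4 (0.46 log units; beyond the scatter) and so runs opposite in direction to a 2.9-fold higher number from compound 1 to compound 2 (0.46 log units; beyond the scatter) where methyl replaced hydrogen. An incoming methyl on this aromatic carbon therefore has no single direction across these two pairs, which also differ in the group that leaves and in where the nitro group stands. Nothing available accounts for the direction of either step. Open, going by these compounds, is how hydrogen, chloro or methoxy at this same place would read against the 4-nitrophenyl partner of compound 3 and compound 4.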